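A few compounds are considered here, and "the series" means these few. Any claim that something is new, unique, unknown or untested is made for them only; others in the source may bear on it.

Compound 1 `NC(N)=NC(=O)c1nc(Cl)c(NCC2CCc3ccccc3C2)nc1N` and compound 2 `NC(N)=NC(=O)c1nc(Cl)c(NCc2cccc(F)c2)nc1N` carry the same core as compound 3 `NC(N)=NC(=O)c1nc(Cl)c(NC2CC2)nc1N`, and both of them have a number. In an assay for inhibition of acid-sensing ion channel 3 (Homo sapiens), read by patch clamp, tested at 1 uM (on this read-out higher numbers stand for more inhibition at the one concentration tested (going by the name of the read-out) and lower numbers for less inhibition), compound 1 gives 44%. In this assay compound 2 gives 29%. Among the compounds with values here, compound 3 stands apart from these two: in this assay compound 3 gives "not determined" (no result reported), so there is no single number to place it on, and the only guidance comes from what compound 1 and compound 2 show.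

Compound 4 `NC(N)=NC(=O)c1nc(Cl)c(Nc2ccccc2)nc1N` differs from compound 3 in one place: phenyl in place of cyclopropyl on a nitrogen on an aromatic ring. Within the data shown here, no step between measured compounds is known here, so the size of the move in this assay cannot be read off directly; the expectation is that compound 4 will fall in the same general region as compound 1 and compound 2, with no firm direction relative to compound 3, whose value is unknown. Compound 4 is expected to give an estimated 30% in this assay. The estimated range for compound 4 runs from 5% to 55%.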

Compound 4, a percentage reported as inhibition, at one concentration (the size of the read-out at that concentration, not a potency): 44%
For compound 4 the middle estimate is 14 percentage points below the measured one; the measured number falls inside the stated range.
By their numbers in this assay, from the lowest: compound 2; then compounds 1 and 4 (each within the scatter of the next).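

No new step can be read from compound 4, as compound 3, which differs from it in one place, has no number in this assay. The compounds shown leave open how the change from cyclopropylamino to anilino shifts inhibition. Nothing here bears on the result for compound 4.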